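The compounds below may be only part of what the source reports. "The series", "measured", "known", "first", "only" and "open" are said of these compounds alone.

Working notes on the series. In a functional assay on liver (Rattus norvegicus, strain Sprague-Dawley) for inhibition, with a stated time of 1 h (a lower number here means a stronger inhibitor, a higher number a weaker inhibitor), compound 1 (`COc1ccc(C(=O)OCC2Oc3ccc([C@H]4Oc5cc(O)cc(O)c5C(=O)[C@@H]4O)cc3OC2c2ccc(O)c(OC)c2)cc1`) gives 21000 nM, compound 2 (`COc1cc(C2Oc3cc([C@H]4Oc5cc(O)cc(O)c5C(=O)[C@@H]4O)ccc3OC2COC(=O)c2cc(OC)c(OC)c(OC)c2)ccc1O`) gives 25700 nM, and compound 3 (`COc1cc(C2Oc3cc([C@H]4Oc5cc(O)cc(O)c5C(=O)[C@@H]4O)ccc3OC2COC(=O)/C=C/c2ccc(C)cc2)ccc1O`) gives 14700 nM, level with the other two within the scatter.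

Compound 4 (`COc1cc(C2Oc3cc([C@H]4Oc5cc(O)cc(O)c5C(=O)[C@@H]4O)ccc3OC2COC(=O)c2ccc(OC)c(OC)c2)ccc1O`) has 3,4-dimethoxyphenyl in place of 2-(4-methylphenyl)ethenyl on a carbonyl carbon.

Among the compounds with values here, three measured steps bear on this change, all at the same place. Two of them exchange 2-(4-methylphenyl)ethenyl for another group: a 1.4-fold lower number from compound 1 to compound 3 (0.15 log units; within the scatter) and a 1.7-fold lower number from compound 2 to compound 3 (0.24 log units; within the scatter). The third exchanges the 4-methoxyphenyl group for the 3,4,5-trimethoxyphenyl group: a 1.2-fold higher number from compound 1 to compound 2 (0.09 log units; within the scatter). None of these steps leaves the scatter, so no clear shift is expected here. Any small movement should be towards a higher number, since compound 1 at 21000 nM and compound 2 at 25700 nM are the closest measured relatives of compound 4.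

In this assay the expected change is a 1.5-fold higher number from compound 3 to compound 4 (0.18 log units; within the scatter), with nothing expected beyond the scatter. For compound 4 the estimated value is 22000 nM, with an expected range from 11000 nM to 42000 nM.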

Compound 4, half-maximal inhibitory concentration: 16000 nM
For compound 4 the middle estimate is 1.4-fold (0.14 log units) above the measured one; low and high end bracket the measured number.
By their numbers in this assay, from the lowest: compounds 3, 4, 1 and 2 (each within the scatter of the next).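

At this place, on a carbonyl carbon, this assay shows a 1.1-fold higher number from compound 3 to compound 4 (0.04 log units; within the scatter) when 3,4-dimethoxyphenyl enters for 2-(4-methylphenyl)ethenyl, so exchanging the ethenyl-linked group for a directly attached aromatic ring stays within the scatter. Compound 4 also connects the methoxy-substituted aromatic groups, with a 1.6-fold lower number from compound 2 to compound 4 (0.21 log units; within the scatter) on losing one methoxy and a 1.3-fold lower number from compound 1 to compound 4 (0.12 log units; within the scatter) on gaining one, and neither step leaves the scatter. No evidence is available to account for these small steps.

Every group shown at this place carries an aromatic ring of carbon only, so the effect of a saturated alkyl chain, an amine or a carboxylic acid remains open. Also open, on these data alone, is whether any group here can move the number beyond the scatter.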